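Benzimidazole series: hydroxy-methoxyphenyl replacing fluorophenyl

The compounds below may be only part of what the source reports. "The series", "measured", "known", "first", "only" and "open" are said of these compounds alone.

Measured so far:
compound 1, `COc1cc(-n2cnc3ccc(-c4cc(F)ccc4F)cc32)cc(OC)c1OC` — 6590 nM
compound 2, `COc1cc(-n2cnc3ccc(-c4ccc(F)cc4)cc32)cc(OC)c1OC` — 3500 nM

In a functional assay on SGC-7901 cells (Homo sapiens) for antiproliferative activity, read by MTT assay, with a stated time of 72 h (on this read-out lower numbers stand for stronger inhibition and higher numbers for weaker inhibition), compound 1 gives 6590 nM and compound 2 gives 3500 nM. Within the data shown here, the only step measured, a 1.9-fold lower number from compound 1 to compound 2 (0.27 log units; within the scatter), does not separate the two compounds beyond the scatter. Compound 2 has the lower of the two numbers, but only by that margin, so it cannot be called the more potent.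

Compound 3, `COc1ccc(-c2ccc3ncn(-c4cc(OC)c(OC)c(OC)c4)c3c2)cc1O`, is not yet measured in this assay. Its change from compound 2 is 3-hydroxy-4-methoxyphenyl in place of 4-fluorophenyl on an aromatic carbon. Among the measured compounds shown here, no measured step involves a 3-hydroxy-4-methoxyphenyl group or a ring carrying a hydrogen-bond donor at this position, so the one measured step gives no direct guide; it only shows that swapping one fluorinated ring for another leaves the number where it was. For compound 3 a modest gain is expected, a 2.3-fold lower number from compound 2 to compound 3 (0.37 log units; beyond the scatter), with a wide range. The estimate for compound 3 in this assay is 1500 nM, between 300 nM and 7000 nM.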

Compound 3, half-maximal inhibitory concentration: 44 nM
Compound 3: middle estimate off by 34-fold (1.53 log units), on the high side, outside the stated range (below it).
By their numbers in this assay, from the lowest: compound 3; then compounds 2 and 1 (each within the scatter of the next).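

In this assay, this aromatic carbon of the shared core proves highly responsive to the group it carries, which the two fluorinated rings did not show, as their numbers lay within the scatter of each other. Placing 3-hydroxy-4-methoxyphenyl in place of 4-fluorophenyl gives an 80-fold lower number from compound 2 to compound 3 (1.90 log units; beyond the scatter), and placing it in place of 2,5-difluorophenyl gives a 150-fold lower number from compound 1 to compound 3 (2.18 log units; beyond the scatter), so both steps are large and the sensitivity of this position is established. No supporting measurement bears on the origin of these steps, so the result stands as a structure-activity observation only.

The hydroxy and methoxy groups enter together, so the share of each in the gain remains unresolved. From the compounds shown here alone, whether an amine or a carboxylic acid in place of the hydroxy would hold this level of activity is also open.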